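Working notes: 4-methoxybenzyl for 4-methoxyphenoxy, compound 4

The source may hold more compounds than are shown below. What is called first, only, known or untested is meant among the compounds shown, and "the series" means these compounds.

Measured values in a functional assay on SK-BR-3 cells (Homo sapiens) for antiproliferative activity; on this read-out lower numbers stand for stronger inhibition and higher numbers for weaker inhibition:
compound 1 `COc1ccc(Oc2ccc3cc(NC(=O)c4ccc(OC(C)=O)c(CC=C(C)C)c4)c(=O)oc3c2C)cc1`: 19500 nM
compound 2 `COc1ccc(Oc2ccc3cc(NC(=O)c4ccc(O)c(CC=C(C)C)c4)c(=O)oc3c2C)cc1`: 42700 nM
compound 3 `COc1ccc(Oc2ccc3cc(NC(=O)c4ccc(OC)c(-c5cccc(OC)c5)c4)c(=O)oc3c2C)cc1`: > 100000 nM, a limit of the assay and not a number

Compound 2 gives the higher of the two numbers in this assay; compound 1 is nearest to it. Within the data shown here, the one step measured between compounds that differ in a single place is a 2.2-fold higher number from compound 1 to compound 2 (0.34 log units; beyond the scatter). Among the measured compounds shown here, compound 3 sits at the limit of > 100000 nM in this assay, at which 1 of the 3 values shown sits; it differs from compound 2 in two places at once, so its limit yields no step of its own.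

Compound 4 `COc1ccc(Cc2ccc3cc(NC(=O)c4ccc(O)c(CC=C(C)C)c4)c(=O)oc3c2C)cc1` differs from compound 2 by 4-methoxybenzyl in place of 4-methoxyphenoxy on an aromatic carbon. For the measured compounds named here, no measured step touches this place: the step from compound 1 to compound 2 alters the oxygen substituent on the benzamide ring, not the linker, and compound 3 gives only a limit. There is thus nothing in the series to point to a direction for this change. The expectation for compound 4 is therefore a number close to that of compound 2, with a wide range and an appreciable chance that this assay returns only a limit. Compound 4 is expected at 45000 nM, between 15000 nM and 150000 nM. That estimate means an expected step of a 1.1-fold higher number from compound 2 to compound 4 (0.02 log units; within the scatter).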

Compound 4, half-maximal inhibitory concentration: 11100 nM
Compound 4: the middle estimate sits 4.1-fold (0.61 log units) above what was measured; measured number outside the range, below it.
By their numbers in this assay, from the lowest: compounds 4 and 1 (each within the scatter of the next); then compound 2. At a limit, above all of these: compound 3.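

In this assay, among these compounds, this position on the core now has a measured step for the first time, since the earlier compounds all carry 4-methoxyphenoxy there: 4-methoxybenzyl in place of 4-methoxyphenoxy gives a 3.8-fold lower number from compound 2 to compound 4 (0.59 log units; beyond the scatter). The place, ortho to a methyl group on the ring of the core, therefore responds to a change between two groups that match in heavy-atom count and in their carbon-only aromatic ring, and differ in their carbon and oxygen counts and in hydrogen-bond acceptor count. Nothing measured in the series ties the step to any one of these differences or to any property of either group.

As far as these compounds go, it remains open whether the same replacement would give a step of similar size on the acetyl-bearing benzamide of compound 1, or on the biaryl benzamide of compound 3, whose value of > 100000 nM is a limit of the assay and not a number. Also open, from the compounds shown here alone, is how this place would respond to an amine or a sulfur atom in the link to the 4-methoxyphenyl ring, to a longer chain there, or to a phenyl ring without the methoxy group.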